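A few compounds are considered here, and "the series" means these few. Any claim that something is new, unique, unknown or untested is made for them only; others in the source may bear on it.

Measured in a functional assay on P388 cells (Mus musculus) for cytotoxicity; on this read-out lower numbers stand for stronger inhibition and higher numbers for weaker inhibition:
compound 1 `C=CCN1C(=O)[C@@H](C)NC(=O)[C@@H]2Cc3ccc(OC)c(c3)Oc3ccc(cc3)C[C@@H](C(=O)N2C)N(C)C(=O)[C@H](C)NC(=O)[C@H](Cc2ccc(OC)cc2)N(C)C(=O)[C@@H]1C`: 18.6 nM
compound 2 `C=C(C)CN1C(=O)[C@@H](C)NC(=O)[C@@H]2Cc3ccc(OC)c(c3)Oc3ccc(cc3)C[C@@H](C(=O)N2C)N(C)C(=O)[C@H](C)NC(=O)[C@H](Cc2ccc(OC)cc2)N(C)C(=O)[C@@H]1C`: 11 nM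
compound 3 `COc1ccc(C[C@H]2C(=O)N[C@@H](C)C(=O)N(C)[C@H]3Cc4ccc(cc4)Oc4cc(ccc4OC)C[C@@H](C(=O)N[C@H](C)C(=O)N(CC=C(C)C)[C@@H](C)C(=O)N2C)N(C)C3=O)cc1`: 6.92 nM

The three compounds share one core and differ only in the chain on the amide-type nitrogen in a ring. Compound 3 stands clear of compound 1, with a 2.7-fold lower number from compound 1 to compound 3 (0.43 log units; beyond the scatter), but cannot be separated from compound 2, with a 1.6-fold lower number from compound 2 to compound 3 (0.20 log units; within the scatter). The remaining measured step, a 1.7-fold lower number from compound 1 to compound 2 (0.23 log units; within the scatter), also stays within the scatter.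

Compound 4 `COc1ccc(C[C@H]2C(=O)N[C@@H](C)C(=O)N(C)[C@H]3Cc4ccc(cc4)Oc4cc(ccc4OC)C[C@@H](C(=O)N[C@H](C)C(=O)N(C/C=C(\C)CCC=C(C)C)[C@@H](C)C(=O)N2C)N(C)C3=O)cc1` extends the same chain of compound 3. The change is 3-methylbut-2-en-1-yl in place of hydrogen on a saturated chain carbon bound to a double-bonded chain carbon. The chain thus grows from 3-methylbut-2-en-1-yl to 3,7-dimethylocta-2,6-dien-1-yl.

All three measured steps alter this same chain, so they are the ones that bear on the change, yet each alters it by less than this one does. The largest of them is only modest, and the series offers no evidence on a chain of this length. A step beyond the scatter is therefore not expected in this assay, and no firm direction can be assigned. The expected change is a 1.4-fold higher number from compound 3 to compound 4 (0.16 log units; within the scatter). For compound 4 the estimated value is 10 nM, with an expected range from 3.5 nM to 30 nM.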

Compound 4, half-maximal inhibitory concentration: 49 nM
Estimate against measurement, compound 4: 4.9-fold (0.69 log units) below, and the stated range ends below it.
By their numbers in this assay, from the lowest: compounds 3, 2 and 1 (each within the scatter of the next, the first and the last beyond it); then compound 4.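

In this assay, the earlier chains on the amide-type nitrogen in a ring spanned only a modest range, whereas growing the chain from 3-methylbut-2-en-1-yl to 3,7-dimethylocta-2,6-dien-1-yl raises the number clearly (a 7.1-fold higher number from compound 3 to compound 4 (0.85 log units; beyond the scatter)). The rise also holds against the two shorter chains (a 4.5-fold higher number from compound 2 to compound 4 (0.65 log units; beyond the scatter); a 2.6-fold higher number from compound 1 to compound 4 (0.42 log units; beyond the scatter)), so compound 4 goes against the fall in the number seen with the chain change that leads to compound 3, and a longer chain at this position is not simply matched by a lower number. No measurement available here bears on the reason for this reversal.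

The compounds shown leave open at which chain length the number starts to rise, since nothing lies in size from 3-methylbut-2-en-1-yl to 3,7-dimethylocta-2,6-dien-1-yl, and whether a saturated decyl chain of similar reach would give the same result. They also leave open how an amine or a carboxylic acid at the far end of such a chain would read in this assay.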